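Adding bromo to a compound at the assay's limit

A few compounds are considered here, and "the series" means these few. Any claim that something is new, unique, unknown or untested is made for them only; others in the source may bear on it.

In a functional assay on U-251 cells (Homo sapiens) (a lower number here means a stronger inhibitor of growth, a higher number a weaker inhibitor of growth), compound 1 `O=S(=O)(/C=C/c1ccc(F)cc1)Cc1ccc(Nc2ncnc3ccccc23)cc1` gives 10 nM. Compound 2 `O=S(=O)(/C=C/c1ccc(F)cc1F)Cc1ccc(Nc2ncnc3ccccc23)cc1` gives > 100000 nM, which is a limit and not a number. Compound 3 `O=S(=O)(/C=C/c1ccc(C(F)(F)F)cc1F)Cc1ccc(Nc2ncnc3ccccc23)cc1` gives 100000 nM.

Compound 4 `O=S(=O)(/C=C/c1ccc(F)cc1F)Cc1ccc(Nc2ncnc3ccc(Br)cc23)cc1` differs from compound 2 on the shared core: bromo in place of hydrogen on an aromatic carbon. The measured steps all lie on the other aromatic ring, so none tests this change directly. Two of them are large: an at least 10000-fold higher number from compound 1 to compound 2 (4.00 log units; beyond the scatter), and a 10000-fold higher number from compound 1 to compound 3 (4.00 log units; beyond the scatter). The third, a number no higher from compound 2 to compound 3 (the limit leaves the size open), has no readable size.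

The first of these steps, an at least 10000-fold higher number from compound 1 to compound 2 (4.00 log units; beyond the scatter), shows that one added fluoro can move this number a long way, so the range must stay wide. Only a modest shift toward a lower number is expected, and the result may well remain a limit. The expected change is an at least 1.6-fold lower number from compound 2 to compound 4 (0.22 log units; that floor lies within the scatter). Compound 4 is estimated at 60000 nM, within a range of 3000 nM to 100000 nM.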

Compound 4, concentration for 50% growth inhibition: 32000 nM
Estimate against measurement, compound 4: 1.9-fold (0.27 log units) above, within the range that was stated.
By their numbers in this assay, from the lowest: compound 1; then compound 4; then compound 3.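

In this assay, among the compounds shown here, bromo in place of hydrogen on the shared core gives an at least 3.1-fold lower number from compound 2 to compound 4 (0.49 log units; beyond the scatter), the first reading here of any change on this six-membered aromatic ring of carbon only. For the compounds shown here, the step shows that this position can shift the number, even though all the earlier steps lay on the other aromatic ring. Its size is only a floor, and compound 2 is the compound that stands at a limit: the limit of > 100000 nM in this assay, at which 1 of the 4 values shown sits.

The compounds shown leave open what bromo at this position does in compound 1, which gives 10 nM, a measured number rather than a limit. Also open, on these data alone, is what an amine, a nitrile or a carboxylic acid would do at the same position, and whether the other carbons of this ring respond as this one does.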